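This account rests on a few compounds, and the source may have more. Where it says the series, first, only, none or still open, it means among the compounds named here.

In a functional assay on HeLa cells (Homo sapiens) for antiproliferative activity, read by MTT assay, with a stated time of 24 h (a higher number here means a weaker inhibitor, a lower number a stronger inhibitor), compound 1 (`Cc1ccc(-c2nn(-c3ccccc3)cc2-c2nc3ccccc3n2S(=O)(=O)c2ccc(F)cc2)cc1`) gives 3670 nM, compound 2 (`Cc1ccc(-c2nn(-c3ccccc3)cc2-c2nc3ccccc3n2S(=O)(=O)c2ccc(Br)cc2)cc1`) gives 2340 nM and compound 3 (`Cc1ccc(-c2nn(-c3ccccc3)cc2-c2nc3ccccc3n2S(=O)(=O)c2ccc(C(F)(F)F)cc2)cc1`) gives 1520 nM. The standing of the trifluoromethyl analogue rests on two steps: a 2.4-fold lower number from compound 1 to compound 3 (0.38 log units; beyond the scatter), and a 1.5-fold lower number from compound 2 to compound 3 (0.19 log units; within the scatter). The remaining pair shows a 1.6-fold lower number from compound 1 to compound 2 (0.20 log units; within the scatter).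

Compound 4 (`O=S(=O)(c1ccc(C(F)(F)F)cc1)n1c(-c2cn(-c3ccccc3)nc2-c2ccc(F)cc2)nc2ccccc21`) has fluoro in place of methyl on an aromatic carbon, para to a large group, which reads as 4-methylphenyl to 4-fluorophenyl: fluoro in place of methyl on an aromatic carbon. All three measured steps change a substituent at another site, so the series holds no direct test of this change and they bear on it only indirectly. The only one beyond the scatter, a 2.4-fold lower number from compound 1 to compound 3 (0.38 log units; beyond the scatter), is modest. No step beyond the scatter is therefore expected in this assay, and no direction can be firmly assigned. The expected step is a 1.2-fold higher number from compound 3 to compound 4 (0.07 log units; within the scatter). For compound 4 the estimated value is 1800 nM, with an expected range of 800 nM to 3900 nM.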

Compound 4, half-maximal inhibitory concentration: 1430 nM
Beside the measured number, compound 4's estimate is 1.3-fold (0.10 log units) above it; the range from low to high includes it.
By their numbers in this assay, from the lowest: compounds 4, 3, 2 and 1 (each within the scatter of the next, the first and the last beyond it).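

In this assay, the methyl-bearing aryl position gets its first direct test, and a 1.1-fold lower number from compound 3 to compound 4 (0.03 log units; within the scatter) does not separate fluoro from methyl on this aromatic carbon, para to a large group. The earlier steps shown here changed only a substituent at another site, whereas this pair shows that, with trifluoromethyl held fixed, 4-methylphenyl and 4-fluorophenyl give numbers that cannot be told apart. No measurement at hand accounts for this result.

Whether the number stays equally unmoved with an amine, a carboxylic acid or a longer chain at this position remains open, since methyl and fluoro are the only groups shown there. Going by these compounds, it is also open whether the match between methyl and fluoro holds when bromo or fluoro replaces the trifluoromethyl group at the other site.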